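Exchange of two equally counted aromatic groups

The compounds below may be only part of what the source reports. "The series", "measured", "known", "first", "only" and "open" are said of these compounds alone.

In a physicochemical assay for lipophilicity, using the shake flask method, measured as octanol-water partition, at pH 7.4 (a lower number here means a more polar compound, a higher number a more lipophilic compound), compound 1 (`CC(=O)N[C@@H]1CCC[C@H](C(=O)Nc2cc(-c3cnc(C)n3C(C)C)ccn2)C1`) gives 1.9 and compound 2 (`CC(=O)N[C@@H]1CCC[C@H](C(=O)Nc2cc(-c3cnn4ccccc34)c(Cl)cn2)C1`) gives 3.6, the higher of the two numbers and beyond the scatter. Compound 3 (`CC(=O)N[C@@H]1CCC[C@H](C(=O)Nc2cc(-c3cnc4ccccn34)c(Cl)cn2)C1`) has the same atoms as compound 2, joined differently: a group of 9 heavy atoms (7 carbon, 2 nitrogen; one five-membered aromatic ring with 2 hetero atoms, one six-membered aromatic ring with 1 hetero atom) in place of a group of 9 heavy atoms (7 carbon, 2 nitrogen; one five-membered aromatic ring with 2 hetero atoms, one six-membered aromatic ring with 1 hetero atom), on an aromatic carbon. The exchange sits on an aromatic carbon, ortho to a chloro group. Going by the values given here, no measured pair covers such an exchange, so the expectation rests on the structural change alone. In this assay a modest fall, slightly beyond the scatter, is expected, estimated as a number 0.60 log units lower from compound 2 to compound 3 (beyond the scatter). For compound 3 the estimated value is 3, with an expected range from 2.5 to 3.5.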

Compound 3, distribution coefficient: 3
Beside the measured number, compound 3's estimate shows no gap at the digits printed, and the stated range covers the measured number.
By their numbers in this assay, from the lowest: compound 1; then compound 3; then compound 2.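

In this assay, the result comes out a number 0.60 log units lower from compound 2 to compound 3 (beyond the scatter), although the two groups have the same atoms and the same counts of rings, donors and acceptors. At this position, ortho to a chloro group, the read-out therefore depends on how the atoms of the group are joined, not only on which atoms it holds. Nothing available explains this step.

As far as these compounds go, compound 1 differs from both compounds in more than one place, so it remains open whether the step holds without the chloro group. From the compounds shown here alone, how an amine or a carboxylic acid on this group would shift the read-out also remains open.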